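A thiophen-3-yl swap at the assay limit

A few compounds are considered here, and "the series" means these few. Any claim that something is new, unique, unknown or untested is made for them only; others in the source may bear on it.

In an ADME assay on HEK293 cells (Homo sapiens) for inhibition, read by MTT assay, with a stated time of 48 h (a higher number here means a weaker inhibitor, a lower number a stronger inhibitor), compound 1 (`CSc1ccc(-c2nc3ccccn3c2Sc2ccccc2)cc1`) gives > 100000 nM, which is a limit of the assay and not a number. Compound 2 (`Clc1ccc(-c2nc3ccccn3c2Sc2ccccc2)cc1`) gives > 100000 nM, which is also only a limit. Together the two measurements amount to the limit of > 100000 nM in this assay, at which 2 of the 2 values shown sit, so compound 2 has no exact value to start from.

Compound 3 (`c1ccc(Sc2c(-c3ccsc3)nc3ccccn23)cc1`) carries thiophen-3-yl in place of 4-chlorophenyl on an aromatic carbon.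

For the measured compounds named here, the one measured step is a step that the two limits leave unreadable from compound 1 to compound 2. Going by the values given here, it has no readable size to carry over, so no step of measurable size is expected in this assay, in either direction. The most likely result is another limit. The expected step, as far as it can be stated, is a number no higher from compound 2 to compound 3 (the limit leaves the size open). For compound 3 the estimated value is 100000 nM, with an expected range from 40000 nM to 300000 nM.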

Compound 3, half-maximal inhibitory concentration: 91700 nM
Beside the measured number, compound 3's estimate is 1.1-fold (0.04 log units) above it; the range from low to high includes it.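

For the compounds shown here, compound 3 is the first compound here to give a number rather than a limit in this assay, so thiophen-3-yl on this aromatic carbon gives the series its first exact value. Replacing 4-chlorophenyl gives an at least 1.0-fold lower number from compound 2 to compound 3 (0.03 log units; that floor lies within the scatter) and replacing 4-(methylsulfanyl)phenyl gives an at least 1.0-fold lower number from compound 1 to compound 3 (0.03 log units; that floor lies within the scatter) and both are only floors, so neither shows a change beyond the scatter. Most of what is shown still rests on a limit and not on a number: the limit of > 100000 nM in this assay, at which 2 of the 3 values shown sit.

On these data alone, it remains open whether a different kind of group at this position, such as an amine or a carboxylic acid, would move the number clearly away from the limit. As far as these compounds go, it is equally open whether thiophen-2-yl, or a replacement of the phenylsulfanyl group, would do so.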